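Ring Enlargement and Sulfur-to-Nitrogen Swap at the Core

The source may hold more compounds than are shown below. What is called first, only, known or untested is meant among the compounds shown, and "the series" means these compounds.

In an ADME assay on cells (Hepatocyte, Homo sapiens) for metabolic stability, with a stated time of 90 min (a higher number here means faster removal of the compound, a lower number slower removal), compound 1 `NC(=O)c1cnc2ccc(-c3cccnc3)cc2c1NC1CCCC1` gives 23 uL/min and compound 2 `NC(=O)c1cnc2ccc(-c3cccnc3)cc2c1SC1CCCC1` gives 18 uL/min. Those two numbers sit within the scatter of each other: a 1.3-fold lower number from compound 1 to compound 2 (0.11 log units; within the scatter). Compound 3 `NC(=O)c1cnc2ccc(-c3cccnc3)cc2c1NC1CCCCC1` differs from compound 2 by cyclohexylamino in place of cyclopentylsulfanyl on an aromatic carbon. For the measured compounds named here, only the step from compound 1 to compound 2 bears on this change, and it reverses the sulfur-for-nitrogen part of it while no measured pair speaks to the larger ring. Compound 3 is therefore expected near compound 1, estimated at 25 uL/min with a range of 12 uL/min to 50 uL/min, a step of a 1.4-fold higher number from compound 2 to compound 3 (0.14 log units; within the scatter) that is not expected to exceed the scatter.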

Compound 3, intrinsic clearance in a liver preparation (reported as CLH), per the amount of preparation that the assay uses: 34 uL/min
The estimate for compound 3 lay 1.4-fold (0.13 log units) below the measured number; the range from low to high includes it.
By their numbers in this assay, from the lowest: compounds 2, 1 and 3 (each within the scatter of the next).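

In this assay the larger ring on the nitrogen can now be read directly, as cyclohexyl in place of cyclopentyl gives a 1.5-fold higher number from compound 1 to compound 3 (0.17 log units; within the scatter) at this position. For the compounds shown here, the double change, cyclohexylamino in place of cyclopentylsulfanyl, gives a 1.9-fold higher number from compound 2 to compound 3 (0.28 log units; within the scatter) and so also separates no compounds here. No evidence is at hand to account for these numbers. Still open, from the compounds shown here alone, is whether an open chain such as isopropylamino, or a ring holding oxygen such as tetrahydropyranylamino, would take the number beyond the scatter. Cyclohexylsulfanyl would be needed to read the ring size on sulfur.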